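The source may hold more compounds than are shown below. What is called first, only, known or untested is meant among the compounds shown, and "the series" means these compounds.

Measured so far in a functional assay for cytotoxicity, read by microscopy; on this read-out lower numbers stand for higher toxicity in this test and higher numbers for lower toxicity in this test:

Compound 1, `CCCCCCCCCCc1cc2cn([C@H]3C[C@H](O)[C@@H](CO)O3)c(=O)nc2o1`, gives > 50000 nM, which is a limit of the assay rather than a number.
Compound 2, `O=c1[nH]c(=O)n([C@H]2C[C@H](O)[C@@H](CO)O2)cc1C#CCCCCCCCCCBr`, gives 50000 nM.
Compound 3, `O=c1[nH]c(=O)n([C@H]2C[C@H](O)[C@@H](CO)O2)cc1C#CCCCCCCCCCI`, gives > 50000 nM, again a limit of the assay.

Compound 1 therefore stands at the edge of what this assay can report; its reading is the limit of > 50000 nM in this assay, at which 2 of the 3 values shown sit. Compound 4, `O=c1nc2oc(CCCCCCCCCCl)cc2cn1[C@H]1C[C@H](O)[C@@H](CO)O1`, differs from compound 1 by chloro in place of methyl on a saturated chain carbon, nine bonds along the chain from an aromatic carbon. Among the measured compounds shown here, only one measured step touches the end of such a chain: a number no lower from compound 2 to compound 3 (the limit leaves the size open), where one halogen replaced another at the chain terminus and the reading stayed at the limit. For the measured compounds named here, no measured step exchanges methyl for chloro, so the evidence is indirect. Given that a halogen swap at the chain end produced no readable movement, compound 4 is expected to change by a number no higher from compound 1 to compound 4 (the limit leaves the size open), that is nothing beyond the scatter. The estimate for compound 4 in this assay is 50000 nM, within 25000 nM to 100000 nM, with a good chance that only a limit is reported again.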

Compound 4, minimum cytotoxic concentration: > 200000 nM
Compound 4 was reported as a limit; the forecaster's own chance of this, stated with the estimate: 75%; middle value at least 4.0-fold (0.60 log units) from the limit.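

In this assay compound 4 gives > 200000 nM, which is a limit of the assay. Compound 1 is also reported only as a limit, so the step between compound 1 and compound 4 cannot be read. The compounds shown leave open whether chloro in place of methyl changes the reading at all.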